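Two aromatic amides diverge; a 3-bromophenyl analogue awaits measurement

The source may hold more compounds than are shown below. What is called first, only, known or untested is meant among the compounds shown, and "the series" means these compounds.

Measured so far:
compound 1 `COC(=O)c1ccc(NC(=O)C2(C(=O)Nc3ccc(Nc4ncc5cc(C(=O)N(C)C)n(C6CCCC6)c5n4)cc3)CC2)cc1` gives 77.1%
compound 2 `CN(C)C(=O)c1cc2cnc(Nc3ccc(NC(=O)C4(C(=O)Nc5cccc(F)c5)CC4)cc3)nc2n1C1CCCC1` gives 33.2%
compound 3 `CN(C)C(=O)c1cc2cnc(Nc3ccc(NC(=O)C4(C(=O)Nc5cccc(C#N)c5)CC4)cc3)nc2n1C1CCCC1` gives 70.8%

All three compounds were tested in a functional assay on A549 cells (Homo sapiens) for inhibition, read by CCK-8 assay, with a stated time of 72 h, tested at 1 uM; on this read-out lower numbers stand for less inhibition of growth and higher numbers for more inhibition of growth at the one concentration tested. Compound 1 has the highest number of the three; compound 3 lies closest to it, and the step of a number 6.3 percentage points lower from compound 1 to compound 3 (within the scatter) stays within the scatter, so no order between compounds 1 and 3 can be claimed. Compound 2 lies furthest away, and the step of a number 43.9 percentage points lower from compound 1 to compound 2 (beyond the scatter) is large.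

Compound 4 `CN(C)C(=O)c1cc2cnc(Nc3ccc(NC(=O)C4(C(=O)Nc5cccc(Br)c5)CC4)cc3)nc2n1C1CCCC1` has not yet been measured. It differs from compound 1 in one place: 3-bromophenyl in place of 4-(methoxycarbonyl)phenyl on an amide-type nitrogen.

Among the measured compounds shown here, two measured steps bear on this change, since both also replace the 4-(methoxycarbonyl)phenyl group on the amide-type nitrogen. One gave a number 43.9 percentage points lower from compound 1 to compound 2 (beyond the scatter), the other a number 6.3 percentage points lower from compound 1 to compound 3 (within the scatter), and between these two the step of a number 37.6 percentage points higher from compound 2 to compound 3 (beyond the scatter) is large. For the measured compounds named here, the measured replacements therefore do not agree, and a 3-bromophenyl group has no direct precedent here. Going by the values given here, a drop beyond the scatter, smaller than the one to compound 2, is expected, namely a number 27.1 percentage points lower from compound 1 to compound 4 (beyond the scatter). Compound 4 is accordingly estimated at 50%, within a range from 25% to 75%.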

Compound 4, percent growth inhibition at one concentration: 20.2%
Estimate against measurement, compound 4: 29.8 percentage points above, and the stated range ends above it.
By their numbers in this assay, from the lowest: compound 4; then compound 2; then compounds 3 and 1 (each within the scatter of the next).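

In this assay, a 3-bromophenyl group on the amide-type nitrogen does not preserve the number seen with 4-(methoxycarbonyl)phenyl, giving a large fall, a number 56.9 percentage points lower from compound 1 to compound 4 (beyond the scatter), so this replacement costs more than the earlier data had indicated. Among the three 3-substituted phenyl amides, the substituent decides the outcome: there is a large fall for a number 50.6 percentage points lower from compound 3 to compound 4 (beyond the scatter), and a modest but real fall for a number 13 percentage points lower from compound 2 to compound 4 (beyond the scatter), which places both halogen compounds well under the nitrile compound 3. Nothing measured here accounts for this order.

The compounds shown leave open whether the methyl ester of compound 1 and the nitrile of compound 3 merely coincide in their numbers, or whether other groups could also hold the number. A carboxylic acid or a primary amide in place of the methyl ester, or an amine on the same phenyl ring, would test this.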